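This account rests on a few compounds, and the source may have more. Where it says the series, first, only, none or still open, it means among the compounds named here.

Working notes on the series.

The series shares one core; compound 1 is `CCOC(=O)c1c(-c2cc(F)cc(OC)c2)[nH]c2cc(OC)ccc2c1=O` and compound 2 is `CCOC(=O)c1c(-c2cccc(OCc3ccccc3)c2)[nH]c2cc(OC)ccc2c1=O`. Both have been run in an ADME assay on Raji cells (Homo sapiens) for cytotoxicity, read by luminescence, with a stated time of 72 h; a higher number here means that more compound is needed for the effect, a lower number that less compound is needed. In this assay compound 1 gives > 21500 nM, which is a limit of the assay and not a number. In this assay compound 2 likewise gives > 21500 nM, again a limit rather than a measured number. Within the data shown here, compound 1 therefore stands at the limit, as does the only other value shown; this is summed up by the limit of > 21500 nM in this assay, at which 2 of the 2 values shown sit. Among the measured compounds shown here, no step between measured compounds can be drawn from two limits, so nothing is known about how changes on the pendant aryl group move this read-out.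

Compound 3, `CCOC(=O)c1c(-c2cccc(CO)c2)[nH]c2cc(OC)ccc2c1=O`, is still to be measured in this assay. It differs from compound 1 by 3-(hydroxymethyl)phenyl in place of 3-fluoro-5-methoxyphenyl on an aromatic carbon. With both measured compounds sitting at the limit, the expectation for the step from compound 1 to compound 3 is none beyond the scatter, and most likely another limit; the expected step that the limit leaves unreadable from compound 1 to compound 3 is set accordingly. Compound 3 is thus estimated at 30000 nM, with a range from 10000 nM to 100000 nM.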

Compound 3, half-maximal effective concentration: > 21500 nM
Compound 3 gave a limit, no number; the forecaster's own chance of this, stated with the estimate: 75%; the middle value is on the limit's open side.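

In this assay, among these compounds, compound 3 gives > 21500 nM, a limit and not a number, and no step among compound 1, compound 2 and compound 3 can be read. The series stands as follows: the limit of > 21500 nM in this assay, at which 3 of the 3 values shown sit.

The compounds shown leave open whether any change on the pendant aryl group moves this read-out at all.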